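The source may hold more compounds than are shown below. What is called first, only, known or untested is meant among the compounds shown, and "the series" means these compounds.

Measured so far:
- compound 1 `O=C(NNc1c(Br)cccc1Br)c1ccc(B(O)O)cc1`: > 100000 nM (a limit)
- compound 2 `O=C(NNc1c(Br)cccc1Br)c1ccc(O)cc1`: > 100000 nM (a limit)

In a toxicity assay on MDCK cells (Canis lupus familiaris) for cytotoxicity, read by CCK-8 assay, with a stated time of 48 h (on this read-out lower numbers stand for higher toxicity in this test and higher numbers for lower toxicity in this test), compound 2 gives > 100000 nM, which is a limit of the assay and not a number. Compound 1 gives > 100000 nM, also a limit. Compound 2 therefore has no numerical position in the series, and the evidence so far amounts to the limit of > 100000 nM in this assay, at which 2 of the 2 values shown sit.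

Compound 3 `O=C(O)c1ccc(C(=O)NNc2c(Br)cccc2Br)cc1` follows from compound 2 through one change: carboxy in place of hydroxy on an aromatic carbon. The new group stands on an aromatic carbon, para to a large group. Within the data shown here, the only measured step that bears on this is the one at an aromatic carbon, a step that the two limits leave unreadable from compound 1 to compound 2. It offers no size to carry over.

No step beyond the scatter is expected in this assay, because the limit of > 100000 nM in this assay, at which 2 of the 2 values shown sit, applies to both compound 1 and compound 2. The expected change is a number no higher from compound 2 to compound 3 (the limit leaves the size open), with no direction favoured. Compound 3 is expected at 100000 nM, with an estimated range from 50000 nM to 200000 nM. A report of only a limit is the likeliest outcome.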

Compound 3, half-maximal cytotoxic concentration: > 100000 nM
Compound 3: a limit, no number (the forecaster's own chance of this, stated with the estimate: 85%); the middle value sits exactly at the limit.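

In this assay compound 3 gives > 100000 nM, a limit of the assay and not a number. Among these compounds, no step can therefore be read among compound 1, compound 2 and compound 3. Whether any group on the aromatic carbon changes the read-out stays open, because the series rests on one limit: the limit of > 100000 nM in this assay, at which 3 of the 3 values shown sit.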